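Cytotoxicity notes: aryl exchange on the ring nitrogen

This account rests on a few compounds, and the source may have more. Where it says the series, first, only, none or still open, it means among the compounds named here.

Measured compounds in an ADME assay on Huh-7 cells (Homo sapiens) for cytotoxicity, read by MTT assay, with a stated time of 72 h; on this read-out higher numbers stand for lower toxicity in this test and lower numbers for higher toxicity in this test:
Compound 1 `Cc1cc(=O)oc2cc(OCc3cn(-c4ccc(F)c(Cl)c4)nn3)ccc12` gives > 100 ug/mL, a limit of the assay.
Compound 2 `Cc1cc(=O)oc2cc(OCc3cn(-c4ccc(F)cc4)nn3)ccc12` gives > 100 ug/mL, also a limit.
Compound 3 `Cc1cc(=O)oc2cc(OCc3cn(-c4ccc(F)cc4F)nn3)ccc12` gives > 100 ug/mL, again a limit.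

Compound 3 thus stands at the limit only; all three values sit there (the limit of > 100 ug/mL in this assay, at which 3 of the 3 values shown sit). Compound 4 `Cc1cc(C)cc(-n2cc(COc3ccc4c(C)cc(=O)oc4c3)nn2)c1` differs by 3,5-dimethylphenyl in place of 2,4-difluorophenyl on an aromatic nitrogen. The steps at this same aryl position bear on it: a step that the two limits leave unreadable from compound 1 to compound 3 and a step that the two limits leave unreadable from compound 2 to compound 3, both unreadable since both ends are limits. The remaining step, a step that the two limits leave unreadable from compound 1 to compound 2, is likewise unreadable. No direction can be read from these, and no step beyond the scatter is expected in this assay. Compound 4 is therefore expected to sit at the limit again, estimated at 150 ug/mL (range 60 ug/mL to 400 ug/mL). The expected step is a step that the limit leaves unreadable from compound 3 to compound 4.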

Compound 4, half-maximal cytotoxic concentration: > 100 ug/mL
Compound 4: a limit, no number (the forecaster's own chance of this, stated with the estimate: 80%); the middle value does not contradict the limit.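

The steps from compound 1, compound 2 and compound 3 to compound 4 cannot be read, as all four compounds sit at one limit: the limit of > 100 ug/mL in this assay, at which 4 of the 4 values shown sit.

The compounds shown leave open whether any aryl exchange on the ring nitrogen changes this read-out.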